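Lengthening the Acid Side Chain on a Fluoroquinoline Antagonist

The compounds below may be only part of what the source reports. "The series", "measured", "known", "first", "only" and "open" are said of these compounds alone.

Of the compounds shown here, three have been tested in a functional assay on ileum (Cavia porcellus) for antagonist activity at cysteinyl leukotriene receptor (Homo sapiens); a lower number here means a stronger inhibitor, a higher number a weaker inhibitor. Compound 1 `CCC(CC)(CC(=O)Nc1cccc(OCc2ccc3cc(C)c(C)cc3n2)c1)C(=O)O` gives 11 nM, and compound 2 `CCC(CC)(CC(=O)Nc1cccc(OCc2ccc3ccc(OC)cc3n2)c1)C(=O)O` gives 80 nM; 80 nM (2 entries). Compound 3 `O=C(O)CCC(=O)Nc1cccc(OCc2ccc3ccc(F)cc3n2)c1` gives 200 nM, the highest number of the set; its gap to compound 1 lies beyond the scatter of repeated measurements, so compound 3 is the weaker inhibitor of those two. Compound 4 `CCCC(CCC)(CC(=O)Nc1cccc(OCc2ccc3ccc(F)cc3n2)c1)C(=O)O` has not yet been measured. It differs from compound 3 in one place: 1-carboxy-1-propylbutyl in place of carboxymethyl on a saturated chain carbon bound to a carbonyl carbon. Within the data shown here, no directly comparable measured pair exists. Compound 1 with 11 nM carries a branched acid chain of this kind and gives the lower number, which points toward a stronger inhibitor. The step is expected to be a 5.0-fold lower number from compound 3 to compound 4 (0.70 log units; beyond the scatter), beyond the scatter. For compound 4 in this assay the expected value is 40 nM, within 10 nM to 150 nM.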

Compound 4, half-maximal inhibitory concentration: 2 nM
Compound 4: the middle estimate sits 20-fold (1.30 log units) above what was measured; measured number below the stated range.
By their numbers in this assay, from the lowest: compound 4; then compound 1; then compound 3.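

On this saturated chain carbon bound to a carbonyl carbon, 1-carboxy-1-propylbutyl in place of carboxymethyl gives a 100-fold lower number from compound 3 to compound 4 (2.00 log units; beyond the scatter) in this assay. The count under this change shows a larger group, with 10 heavy atoms instead of 4, but the same two oxygens, so the added atoms are all carbon. No measurement here accounts for the size of this step. The compounds shown leave open whether a single propyl group or two methyl groups on that carbon would give a similar step.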